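Compound 2 to compound 4: a thiophene exchange

The source may report more compounds than this note shows. Statements on the series, on what has been measured and on what is new or still open speak of the compounds shown alone.

compound 1 `Clc1ccc(-c2cc(-c3ccoc3)cc(-c3ccco3)n2)s1`: 22700 nM
compound 2 `Cc1ccsc1-c1cc(-c2ccc(Cl)o2)cc(-c2ccco2)n1`: 22200 nM
compound 3 `Cc1ccsc1-c1cc(-c2ccc(Cl)o2)cc(-c2cccnc2)n1`: > 50000 nM, a limit of the assay

In a functional assay on HeLa cells (Homo sapiens) for cytotoxicity, read by ELISA, with a stated time of 4 days (on this read-out lower numbers stand for stronger inhibition and higher numbers for weaker inhibition), compound 2 gives 22200 nM, within the scatter of compound 1 at 22700 nM. Compound 3 reports no number, only the limit > 50000 nM.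

Compound 4 `Clc1ccc(-c2cc(-c3ccco3)nc(-c3ccc(Cl)s3)c2)o1` has 5-chlorothiophen-2-yl in place of the 3-methylthiophen-2-yl of compound 2, on an aromatic carbon next to the ring nitrogen: 5-chlorothiophen-2-yl in place of 3-methylthiophen-2-yl on an aromatic carbon.

Going by the values given here, the one measured step, an at least 2.2-fold higher number from compound 2 to compound 3 (0.35 log units; beyond the scatter), exchanges furan-2-yl for pyridin-3-yl and so concerns a different group, which makes it only a loose guide to the size of change possible. The closer evidence is compound 1, which carries 5-chlorothiophen-2-yl next to the ring nitrogen and gives 22700 nM, although it also differs from compound 4 elsewhere. On that basis, no step beyond the scatter is expected in this assay, in either direction.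

For compound 4 the estimated value is 20000 nM, with an expected range from 9000 nM to 45000 nM. This estimate corresponds to an expected 1.1-fold lower number from compound 2 to compound 4 (0.05 log units; within the scatter).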

Compound 4, half-maximal inhibitory concentration: > 50000 nM
Compound 4 was reported as a limit; the forecaster's own chance of this, stated with the estimate: 20%; middle value at least 2.5-fold (0.39 log units) away from the limit.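

In this assay, going by these compounds alone, the position next to the ring nitrogen responds to a change on the thiophene, which the earlier compounds did not show: 5-chlorothiophen-2-yl in place of 3-methylthiophen-2-yl gives an at least 2.2-fold higher number from compound 2 to compound 4 (0.35 log units; beyond the scatter). The entering group does not settle the outcome alone, since compound 1 carries the same 5-chlorothiophen-2-yl and gives 22700 nM, while 5-chlorofuran-2-yl in place of its furan-3-yl gives an at least 2.2-fold higher number from compound 1 to compound 4 (0.34 log units; beyond the scatter), so among these compounds the result at this position goes with the other aryl group on the shared core. The reading for compound 4 is a limit and not a number, so both steps give only a minimum size and compound 4 cannot be ordered against compound 3, the other compound reported this way: the limit of > 50000 nM in this assay, at which 2 of the 4 values shown sit.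

On these data alone, how far compound 4 lies past that limit stays open, and so does whether the loss comes from adding the chlorine at the 5-position of the thiophene or from removing the methyl at its 3-position. Also open, as far as these compounds go, is what an amine or a carboxylic acid on the thiophene would give at this position.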